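Ghrelin receptor ureas: pyrazolyl in place of pyrrolidinyl

The compounds below may be only part of what the source reports. "The series", "measured", "known", "first", "only" and "open" are said of these compounds alone.

Measured so far in an assay on HEK293 cells for displacement of a labelled ligand from growth hormone secretagogue receptor type 1 (Homo sapiens), with a stated time of 60 min; on this read-out lower numbers stand for stronger inhibition and higher numbers for weaker inhibition:
compound 1, `CN1CCN(CCCS(=O)(=O)c2ccc3nc(NC(=O)NC(=O)c4cccc(-n5cccn5)c4Cl)sc3c2)CC1`, 8.8 nM
compound 2, `CCN(CC)CCCS(=O)(=O)c1ccc2nc(NC(=O)NC(=O)c3cc(-n4cccn4)ccc3Cl)sc2c1`, 3.9 nM
compound 3, `CN1CCC(S(=O)(=O)c2ccc3nc(NC(=O)NC(=O)c4cc(N5CCCC5)ccc4Cl)sc3c2)CC1`, 0.92 nM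

All three compounds share the same acyl urea core and differ in the sulfonyl tail and in the group on the chlorophenyl ring. Compound 3 gives the lowest number of the three in this assay ; its nearest neighbour is compound 2, and the gap to both compound 2 and compound 1 lies beyond the scatter, so compound 3 stands as the most potent of the measured set.

Compound 4, `CN1CCC(S(=O)(=O)c2ccc3nc(NC(=O)NC(=O)c4cc(-n5cccn5)ccc4Cl)sc3c2)CC1`, keeps the sulfonyl tail of compound 3 and changes only the group on the chlorophenyl ring: 1H-pyrazol-1-yl in place of pyrrolidin-1-yl on an aromatic carbon. For the measured compounds named here, no measured pair differs in just this way, so the size of the step is not known from the data. Compound 2 carries the same pyrazolyl group at the same position with another tail and sits higher than compound 3, which argues for a modest rise in the number rather than a fall. For compound 4 the expected step is a 2.2-fold higher number from compound 3 to compound 4 (0.34 log units; beyond the scatter), a small move that may stay within the scatter. Compound 4 is therefore estimated at 2 nM in this assay , with a range from 0.6 nM to 6.5 nM.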

Compound 4, half-maximal inhibitory concentration: 15 nM
The estimate for compound 4 lay 7.5-fold (0.88 log units) below the measured number, outside the stated range (above it).
By their numbers in this assay, from the lowest: compound 3; then compound 2; then compounds 1 and 4 (each within the scatter of the next).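

In this assay, for the compounds shown here, the step of a 16-fold higher number from compound 3 to compound 4 (1.21 log units; beyond the scatter) is the first direct reading of this position, on an aromatic carbon meta to a large group and para to a chloro group, and with the 1-methylpiperidin-4-yl tail held constant it clearly favours 2-chloro-5-(pyrrolidin-1-yl)phenyl over 2-chloro-5-(1H-pyrazol-1-yl)phenyl. With the 1H-pyrazol-1-yl group held constant, the step of a 3.8-fold higher number from compound 2 to compound 4 (0.59 log units; beyond the scatter) shows that 1-methylpiperidin-4-yl in place of 3-(diethylamino)propyl on the sulfonyl sulfur also raises the number, so the low value of compound 3 cannot be credited to its tail alone. Nothing at hand explains either step.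

The compounds shown do not tell whether pyrrolidin-1-yl lowers the number by a similar amount on the 3-(diethylamino)propyl tail. They also leave open whether the step follows the aromatic ring or the second ring nitrogen, a question that 1H-pyrrol-1-yl or imidazol-1-yl at the same position could help separate, while piperidin-1-yl would test the size of the non-aromatic ring.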